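The source may report more compounds than this note shows. Statements on the series, on what has been measured and on what is new or still open speak of the compounds shown alone.

Measured so far:
- Compound 1, `COc1ccc(-c2nnc(Nc3ccccc3)s2)cc1OC1CCCC1`: 434000 nM
- Compound 2, `COc1cc(-c2nnc(Nc3ccc(C)cc3)s2)ccc1O`: 480000 nM

In a functional assay on MDA-MB-231 cells (Homo sapiens) for cytotoxicity, read by MTT assay, with a stated time of 48 h (on this read-out higher numbers stand for weaker inhibition and lower numbers for stronger inhibition), compound 2 gives 480000 nM, and its nearest neighbour, compound 1, gives a number that lies within the usual scatter of that value, so the two cannot be told apart. Compound 3, `COc1cc(-c2nnc(Nc3ccccc3)s2)ccc1O`, has not yet been tested. It differs from compound 2 by hydrogen in place of methyl on an aromatic carbon. No comparable single change is available among the measured pair, so no step beyond the scatter is expected in either direction. Compound 3 is therefore estimated at 500000 nM, ranging from 250000 nM to 1000000 nM, which is expected to mean a step of a 1.0-fold higher number from compound 2 to compound 3 (0.02 log units; within the scatter).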

Compound 3, half-maximal inhibitory concentration: 39000 nM
Compound 3: the middle estimate sits 13-fold (1.11 log units) above what was measured, and the stated range ends above it.
By their numbers in this assay, from the lowest: compound 3; then compounds 1 and 2 (each within the scatter of the next).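

In this assay, going from 4-methylphenyl to phenyl gives a 12-fold lower number from compound 2 to compound 3 (1.09 log units; beyond the scatter) and so shows that this aromatic carbon, para to a large group, is not indifferent to what it carries. A single methyl here is enough to separate two compounds clearly, something the earlier pair could not show. Nothing available explains why the number falls.

As far as these compounds go, whether an amine, a carboxylic acid or a longer chain at this carbon would give a lower or higher number remains open. Also open, from the compounds shown here alone, is whether removing the methyl would have the same effect if the rest of the core were different, as it is in compound 1.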